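This account rests on a few compounds, and the source may have more. Where it says the series, first, only, none or still open, it means among the compounds named here.

Three compounds share a core and differ only in the aryl group on the sulfonamide nitrogen. Compound 1 `CCCCc1ccc(NS(=O)(=O)c2ccc(N3CCNC3=O)cc2)cc1` gives 450 nM in a functional assay on M21 cells (Homo sapiens) for antiproliferative activity, read by sulforhodamine B assay, with a stated time of 48 h; on this read-out lower numbers stand for stronger inhibition and higher numbers for weaker inhibition. Compound 2 `CCc1ccc(NS(=O)(=O)c2ccc(N3CCNC3=O)cc2)cc1` gives 480 nM in this assay, and compound 3 `CCCCOc1ccc(NS(=O)(=O)c2ccc(N3CCNC3=O)cc2)cc1` gives 580 nM in this assay. Compound 2 thus sits second highest of the three numbers, but every gap is small: a 1.1-fold higher number from compound 1 to compound 2 (0.03 log units; within the scatter), a 1.2-fold higher number from compound 2 to compound 3 (0.08 log units; within the scatter) and a 1.3-fold higher number from compound 1 to compound 3 (0.11 log units; within the scatter) all fall within the scatter, so the three compounds cannot be ordered.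

Compound 4 `O=C1NCCN1c1ccc(S(=O)(=O)Nc2cccc(Cl)c2)cc1` has not yet been measured in this assay. Relative to compound 2 the change is 3-chlorophenyl in place of 4-ethylphenyl on a sulfonamide nitrogen. The measured steps bear on it only loosely, since they exchange one chain or alkoxy group for another on the same aryl carbon and none puts a chlorine on the ring; they show that such changes on this aryl group moved this assay by no more than the scatter. On that basis compound 4 is expected to stay close to compound 2, with a step of a 1.3-fold higher number from compound 2 to compound 4 (0.10 log units; within the scatter) that need not exceed the scatter. The estimate for compound 4 in this assay is therefore 600 nM, between 250 nM and 1500 nM.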

Compound 4, half-maximal inhibitory concentration: 25 nM
Beside the measured number, compound 4's estimate is 24-fold (1.38 log units) above it, outside the stated range (below it).
By their numbers in this assay, from the lowest: compound 4; then compounds 1, 2 and 3 (each within the scatter of the next).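

Putting 3-chlorophenyl in place of 4-ethylphenyl on a sulfonamide nitrogen gives a 19-fold lower number from compound 2 to compound 4 (1.28 log units; beyond the scatter) in this assay, so the aryl group at this place can strongly change the read-out. The earlier exchanges of chain and butoxy groups had stayed within the scatter and gave no sign of such sensitivity. Nothing shown accounts for the size of this step.

The single step removes the ethyl group, brings in chlorine and moves the substituent to another ring carbon, so the compounds shown leave open which of these changes carries the effect; 4-chlorophenyl and 3-ethylphenyl groups on the same nitrogen would separate them. Also open, going by these compounds, is how plain phenyl, 3-fluorophenyl or 3-bromophenyl would compare with 3-chlorophenyl.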